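The compounds below may be only part of what the source reports. "The series", "measured", "known", "first", "only" and "open" are said of these compounds alone.

In an assay on membranes from Cortex for displacement of a labelled ligand from Sigma non-opioid intracellular receptor 1 (Cavia porcellus), read by scintillation counting, with a stated time of 120 min (on this read-out lower numbers stand for stronger inhibition and higher numbers for weaker inhibition), compound 1 `Fc1ccc(C(SCCNC2CCN(Cc3ccc(Cl)cc3)CC2)c2ccc(F)cc2)cc1` gives 45.5 nM. Compound 2 `OC(Cc1ccccc1)CN1CCC(NCCSC(c2ccc(F)cc2)c2ccc(F)cc2)CC1` gives 309 nM and compound 3 `[O-][S+](CCNC1CCN(CC(O)Cc2ccccc2)CC1)C(c1ccc(F)cc1)c1ccc(F)cc1` gives 351 nM. Compound 2 thus holds the second highest of the three numbers: compound 3 sits within the scatter of it, while compound 1 lies well below. For the measured compounds named here, the one measured step in this set, a 6.8-fold higher number from compound 1 to compound 2 (0.83 log units; beyond the scatter), shows that exchanging the group on the ring amine nitrogen moves the read-out by a modest but real amount.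

Compound 4 `O=C(c1cc2ccccc2[nH]1)N1CCC(NCCSC(c2ccc(F)cc2)c2ccc(F)cc2)CC1` carries the change ((1H-indol-2-yl)carbonyl in place of 2-hydroxy-3-phenylpropyl on an amine nitrogen in a ring). This touches the same ring nitrogen as the step from compound 1 to compound 2, so that step is the only measured one that bears on it, and it was modest. Compounds 2 and 3 differ elsewhere in the molecule and their values sit within the scatter of each other, so they say nothing about this position. Going by the values given here, no measured compound carries a carbonyl on that nitrogen, so the direction is open; a step of roughly the size seen before, in either direction and centred near the number for compound 2, is the working assumption. Compound 4 is therefore expected to come in at 200 nM, with a range of 50 nM to 800 nM, which means an estimated step of a 1.5-fold lower number from compound 2 to compound 4 (0.19 log units; within the scatter).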

Compound 4, inhibition constant: 1130 nM
Compound 4: the middle estimate sits 5.7-fold (0.75 log units) below what was measured, and the stated range ends below it.
By their numbers in this assay, from the lowest: compound 1; then compounds 2 and 3 (each within the scatter of the next); then compound 4.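

In this assay, the ring amine nitrogen now carries three groups whose numbers separate beyond the scatter: the move from 2-hydroxy-3-phenylpropyl to (1H-indol-2-yl)carbonyl goes upward (a 3.7-fold higher number from compound 2 to compound 4 (0.56 log units; beyond the scatter)), and the move from 4-chlorobenzyl to the same group is large (a 25-fold higher number from compound 1 to compound 4 (1.40 log units; beyond the scatter)). Among these three compounds, the only group with a carbonyl on this nitrogen gives the highest number, so the direction for this change is no longer open for this one example. The leaving and entering groups have the same counts of hydrogen-bond donors and acceptors, so those counts do not separate compound 2 from compound 4, and no measurement shown accounts for the shift.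

Going by these compounds, whether the higher number goes with the carbonyl or with the five-membered aromatic ring remains open, and a (1H-indol-2-yl)methyl or a benzoyl group on the same nitrogen would separate the two. Whether the same change gives a step of similar size on the core of compound 3 is also unresolved.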